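Swapping an oxazole for a cyclic sulfonamide: stability outlook

The source may report more compounds than this note shows. Statements on the series, on what has been measured and on what is new or still open speak of the compounds shown alone.

Measured in an ADME assay on microsomes from liver (Rattus norvegicus) for metabolic stability; a higher number here means that the compound lasts longer, a lower number that the compound disappears faster:
Compound 1 `CC(C)C(c1noc(=O)[nH]1)c1ccc(-c2ccc3cccc(F)c3c2)[nH]c1=O` — > 3 h, a limit of the assay
Compound 2 `CC(C)C(CC(N)=O)c1ccc(-c2ccc3cccc(F)c3c2)[nH]c1=O` — < 0.0667 h, a limit of the assay
Compound 3 `CC(C)C(c1ncco1)c1ccc(-c2ccc3cccc(F)c3c2)[nH]c1=O` — 0.0983 h

Among the measured compounds shown here, compound 3 holds the only actual number among the three; the two other values are limits. Compound 4 `CC(C)C(c1ccc(-c2ccc3cccc(F)c3c2)[nH]c1=O)N1CCCCS1(=O)=O` differs from compound 3 by a group of 8 heavy atoms (4 carbon, 1 nitrogen, 2 oxygen, 1 sulfur; one six-membered non-aromatic ring with 2 hetero atoms) in place of a group of 5 heavy atoms (3 carbon, 1 nitrogen, 1 oxygen; one five-membered aromatic ring with 2 hetero atoms), on a saturated chain carbon bound to an aromatic carbon and a saturated chain carbon. Two measured steps at this same place were large: an at least 44-fold lower number from compound 1 to compound 2 (1.65 log units; beyond the scatter) and an at least 30-fold lower number from compound 1 to compound 3 (1.48 log units; beyond the scatter). The step of an at least 1.4-fold higher number from compound 2 to compound 3 (0.16 log units; that floor lies within the scatter) was small. Changes at this carbon can therefore move the number far, but the direction for the ring entering here is not settled by these compounds. The expected step is a 2.0-fold higher number from compound 3 to compound 4 (0.31 log units; beyond the scatter). Compound 4 is estimated at 0.2 h, expected to fall between 0.05 h and 1.5 h.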

Compound 4, half-life: 0.07 h
Compound 4: middle estimate off by 2.9-fold (0.46 log units), on the high side; measured number inside the range.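

Putting a six-membered non-aromatic ring in place of 1,3-oxazol-2-yl changes little in this assay: a 1.4-fold lower number from compound 3 to compound 4 (0.15 log units; within the scatter). Two further steps start from limits of the assay, so each gives only a floor: an at least 1.0-fold higher number from compound 2 to compound 4 (0.02 log units; that floor lies within the scatter) and an at least 42-fold lower number from compound 1 to compound 4 (1.63 log units; beyond the scatter). Among the four groups tried on this carbon, the new ring therefore stays with those of compound 2 and compound 3, and only compound 1 stands far apart.

On these data alone, whether an amine or a carboxylic acid here would last as long as compound 1 remains open. So does which part of the ring in compound 1 sets it apart.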